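Ethoxy in place of carboxyethyl on the benzylamide series

This account rests on a few compounds, and the source may have more. Where it says the series, first, only, none or still open, it means among the compounds named here.

Compound 1 `CC(C)(C)c1ccc(C(=O)NCc2ccc(C(N)=O)cc2)cc1` gives 3800 nM in an assay on HeLa cells with Bile acid receptor (Homo sapiens) as the target, read by a luciferase reporter, with a stated time of 24 h (a lower number here means that less compound is needed, a higher number that more compound is needed for the effect), compound 2 `CC(C)(C)c1ccc(C(=O)NCc2ccc(NS(C)(=O)=O)cc2)cc1` gives 44 nM, and compound 3 `CC(C)(C)c1ccc(C(=O)NCc2ccc(CCC(=O)O)cc2)cc1` gives 350 nM. Compound 3 thus stands second highest of the three numbers, with an 8.0-fold higher number from compound 2 to compound 3 (0.90 log units; beyond the scatter) and an 11-fold lower number from compound 1 to compound 3 (1.04 log units; beyond the scatter). Compound 4 `CCOc1ccc(CNC(=O)c2ccc(C(C)(C)C)cc2)cc1` differs from compound 3 by ethoxy in place of 2-carboxyethyl on an aromatic carbon. Among the compounds with values here, no measured step exchanges the 2-carboxyethyl for an ethoxy group, but both steps on this aromatic carbon were beyond the scatter, so a change of similar size is expected rather than none. The estimated step is a 4.3-fold higher number from compound 3 to compound 4 (0.63 log units; beyond the scatter), upward, since compound 3 already sits an 11-fold lower number from compound 1 to compound 3 (1.04 log units; beyond the scatter) from the weakest compound. For compound 4 the expected value in this assay is 1500 nM, within 300 nM to 8000 nM.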

Compound 4, half-maximal effective concentration: 160 nM
For compound 4 the middle estimate is 9.4-fold (0.97 log units) above the measured one; measured number below the stated range.
By their numbers in this assay, from the lowest: compound 2; then compound 4; then compound 3; then compound 1.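

On this aromatic carbon, para to a large group, ethoxy gives a 2.2-fold lower number from compound 3 to compound 4 (0.34 log units; beyond the scatter) in this assay and a 24-fold lower number from compound 1 to compound 4 (1.38 log units; beyond the scatter) with 0 hydrogen-bond donors in the group. A hydrogen-bond donor at this place is therefore not needed for a number well under that of compound 1, yet ethoxy does not match methanesulfonamido, with a 3.6-fold higher number from compound 2 to compound 4 (0.56 log units; beyond the scatter) as the step between them. No measured evidence bearing on these steps is available. From the compounds shown here alone, whether methoxy, a longer alkoxy chain or an amine on this carbon would bring the number closer to that of compound 2 stays open.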